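The compounds below may be only part of what the source reports. "The series", "measured", "known", "first", "only" and "open" are said of these compounds alone.

Measured in an ADME assay on HEL cells (Homo sapiens) for inhibition; a higher number here means that more compound is tolerated, a lower number that less compound is tolerated:
- compound 1 `CCCCCc1ccc(-c2cc3cn([C@H]4C[C@H](O)[C@@H](COC(=O)[C@H](CC(C)C)NC(=O)[C@@H]5CCCN5C(=O)[C@@H](N)C(C)C)O4)c(=O)nc3o2)cc1`: 31000 nM
- compound 2 `CCCCCc1ccc(-c2cc3cn([C@H]4C[C@H](O)[C@@H](COC(=O)[C@H](C)NC(=O)[C@@H]5CCCN5C(=O)[C@@H](N)C(C)C)O4)c(=O)nc3o2)cc1`: 44000 nM
- compound 3 `CCCCCc1ccc(-c2cc3cn([C@H]4C[C@H](O)[C@@H](COC(=O)[C@@H](NC(=O)[C@@H]5CCCN5C(=O)[C@@H](N)CC(N)=O)C(C)C)O4)c(=O)nc3o2)cc1`: 56000 nM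

Compound 3 (at 56000 nM) has the highest number of the three, but it lies within the usual scatter of both compound 1 and compound 2, so the series gives no real separation. Compound 4 `CCCCCc1ccc(-c2cc3cn([C@H]4C[C@H](O)[C@@H](COC(=O)[C@@H](NC(=O)[C@@H]5CCCN5C(=O)[C@@H](N)CCCCN)C(C)C)O4)c(=O)nc3o2)cc1` carries 3-aminopropyl in place of carbamoyl on a saturated chain carbon, two bonds along the chain from an amine nitrogen and a carbonyl carbon.

Going by the values given here, no measured step makes this replacement. The only one available, from isopropyl to hydrogen elsewhere in the molecule (a 1.4-fold higher number from compound 1 to compound 2 (0.15 log units; within the scatter)), stayed within the scatter, and it bears on this change only indirectly. With so little evidence, no change beyond the scatter is expected in this assay for compound 4 (estimated step: a 1.2-fold lower number from compound 3 to compound 4 (0.09 log units; within the scatter)). The estimate for compound 4 is 45000 nM, with an expected range from 20000 nM to 90000 nM.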

Compound 4, half-maximal cytotoxic concentration in the HEL assay: 29000 nM
Estimate against measurement, compound 4: 1.6-fold (0.19 log units) above; the range from low to high includes it.
By their numbers in the HEL assay, from the lowest: compounds 4, 1, 2 and 3 (each within the scatter of the next).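

Going by these compounds alone, in the HEL assay compound 3 gives 56000 nM and compound 4 gives 29000 nM; the first measured change at this place, 3-aminopropyl in place of carbamoyl on a saturated chain carbon, two bonds along the chain from an amine nitrogen and a carbonyl carbon, gives a 1.9-fold lower number from compound 3 to compound 4 (0.29 log units; within the scatter) and so stays within the scatter. In a physicochemical assay for solubility, with a stated time of 24 h (a higher number here means a more soluble compound, a lower number a less soluble compound), compound 3 gives 39000 ug/mL and compound 4 gives 55000 ug/mL; the same replacement gives a 1.4-fold higher number from compound 3 to compound 4 (0.15 log units; within the scatter) and is also printed as within the scatter, so neither read-out separates the two groups at this place. Nothing measured here accounts for either step.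

The compounds shown leave open whether a carboxylic acid or a longer chain ending in an amine at this place would move either number beyond the scatter. They also leave open whether a hydroxyl group there would behave like carbamoyl or 3-aminopropyl in these two assays.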